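A Second Methoxy on the Core of Compound 1

The source may hold more compounds than are shown below. What is called first, only, known or untested is meant among the compounds shown, and "the series" means these compounds.

Measured compounds and their numbers in a functional assay on PC-3 cells (Homo sapiens) for cytotoxicity, read by MTT assay, with a stated time of 72 h; a higher number here means a weaker inhibitor, a lower number a stronger inhibitor:
compound 1 `COc1cccc(/C=C/C(=O)Nc2cc(C(=O)c3cc(OC)c(OC)c(OC)c3)ccc2OC)c1` gives 4700 nM
compound 2 `COc1ccc(C(=O)c2cc(OC)c(OC)c(OC)c2)cc1NC(=O)/C=C/c1ccc(N)cc1` gives 15900 nM
compound 3 `COc1ccc(C(=O)c2cc(OC)c(OC)c(OC)c2)cc1NC(=O)/C=C/c1ccc([N+](=O)[O-])cc1` gives 10400 nM

Compound 1 has the lowest number of the three. Against it, compound 3 shows a 2.2-fold higher number from compound 1 to compound 3 (0.34 log units; beyond the scatter) and compound 2 shows a 3.4-fold higher number from compound 1 to compound 2 (0.53 log units; beyond the scatter); between them, a 1.5-fold lower number from compound 2 to compound 3 (0.18 log units; within the scatter). Compound 4 `COc1cccc(/C=C/C(=O)Nc2cc(C(=O)c3cc(OC)c(OC)c(OC)c3)cc(OC)c2OC)c1` is not yet measured. It differs from compound 1 by methoxy in place of hydrogen on an aromatic carbon, placed on an aromatic carbon of a six-membered ring of carbon only, ortho to a methoxy group and meta to two large groups. Among the compounds with values here, none of the measured steps touches that ring; all three change the other aryl group. So no step bears on this change, and compound 4 is expected to give 4700 nM (range 1500 nM to 15000 nM), an estimated no change at the digits printed from compound 1 to compound 4 (within the scatter).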

Compound 4, half-maximal inhibitory concentration: 13300 nM
Compound 4: middle estimate off by 2.8-fold (0.45 log units), on the low side; measured number inside the range.
By their numbers in this assay, from the lowest: compound 1; then compounds 3, 4 and 2 (each within the scatter of the next).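

In this assay methoxy in place of hydrogen on an aromatic carbon gives a 2.8-fold higher number from compound 1 to compound 4 (0.45 log units; beyond the scatter) on the core of compound 1. Within the data shown here, this is the first sign that this ring responds to a change at this position, since the earlier steps all altered the other aryl group. Nothing shown gives a reason for the rise.

On these data alone, whether a fluorine atom or a hydroxyl group at this position would also raise the number remains open, as does whether methoxy here would act the same way alongside the other aryl groups of compound 2 and compound 3.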